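The compounds below may be only part of what the source reports. "The series", "measured", "known", "first", "only" and "open" are said of these compounds alone.

Working notes on the series. Among the compounds with values here, compound 1 `COc1c(OCCCCN2CCNCC2)cc(O)c2c(=O)cc(-c3ccccc3)oc12` is the only member with a number so far: in a functional assay on A549 cells (Homo sapiens) for cytotoxicity, read by MTT assay, with a stated time of 48 h (on this read-out lower numbers stand for stronger inhibition and higher numbers for weaker inhibition), compound 1 gives 1740 nM. Compound 2 `COc1c(O)cc(O)c2c(=O)cc(-c3ccc(C)cc3)oc12` and compound 3 `COc1c(O)cc(O)c2c(=O)cc(-c3ccc(F)cc3)oc12` carry no result in this assay: compound 2 stands at "not determined" (no result reported) and compound 3 stands at "not determined" (no result reported), so no comparison to compound 1 can be drawn from them. Compound 4 `COc1c(OCCCN2CCCC2)cc(O)c2c(=O)cc(-c3ccccc3)oc12` is the next entry and differs from compound 1 in one place: pyrrolidin-1-yl in place of (piperazin-1-yl)methyl on a saturated chain carbon, three bonds along the chain from an oxygen on an aromatic ring. Within the data shown here, no measured pair in the set probes this change, so the expectation rests on compound 1 alone. The step from compound 1 to compound 4 in this assay is expected to be small, a 1.2-fold lower number from compound 1 to compound 4 (0.06 log units; within the scatter), not clearly beyond the usual scatter in either direction. Compound 4 is therefore estimated at 1500 nM, within 600 nM to 4000 nM.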

Compound 4, half-maximal inhibitory concentration: 1390 nM
Beside the measured number, compound 4's estimate is 1.1-fold (0.03 log units) above it, and the stated range covers the measured number.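

The step in this assay is a 1.3-fold lower number from compound 1 to compound 4 (0.10 log units; within the scatter) and the two compounds cannot be told apart on this read-out. This first measured pair at this position shows that 3-(pyrrolidin-1-yl)propyl can stand in place of 4-(piperazin-1-yl)butyl with no step beyond the scatter, although the ring and the chain differ together. Nothing on hand bears on this result.

The ring and the chain length cannot be separated from this single pair. As far as these compounds go, how a morpholine or a dimethylamino group at the chain end would read also stays open.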